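Hydroxy to Anilino on a Carbonyl: Little Change Expected

A few compounds are considered here, and "the series" means these few. Any claim that something is new, unique, unknown or untested is made for them only; others in the source may bear on it.

Compound 1 `CC(=O)SCCC(CCCCC(=O)O)SC(C)=O`: 7.24%
Compound 2 `O=C(O)CCCCC(CCSC(=O)c1ccccc1)SC(=O)c1ccccc1`: "not active" (no number reported)
Compound 3 `CC(=O)SCCC(CCCCC(=O)Nc1ccccc1)SC(C)=O`: 7.24%

In a functional assay on KB cells (Homo sapiens) for inhibition, read by MTT assay, with a stated time of 24 h, tested at 0.1 ug/mL (on this read-out higher numbers stand for more inhibition of growth at the one concentration tested and lower numbers for less inhibition of growth), compound 1 gives 7.24%. Compound 3 differs from it by one change, (anilino in place of hydroxy on a carbonyl carbon), and the step of no change at the digits printed from compound 1 to compound 3 (within the scatter). Compound 2 carries a core whose difference from that of compound 1 is not broken down here; in this assay compound 2 is reported as "not active" (no number reported), without a number.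

Compound 4 `O=C(CCCCC(CCSC(=O)c1ccccc1)SC(=O)c1ccccc1)Nc1ccccc1` has not yet been measured. It differs from compound 2 by the same change, (anilino in place of hydroxy on a carbonyl carbon), at the same kind of place. Because the earlier step of no change at the digits printed from compound 1 to compound 3 (within the scatter) stayed within the scatter, a similarly small step from compound 2 to compound 4 is expected, starting from a compound with no reported activity. Compound 4 is therefore estimated to give 5% in this assay, with a likely range from 0% to 15%.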

Compound 4, percent growth inhibition at one concentration: 1.52%
Compound 4: middle estimate off by 3.5 percentage points, on the high side; measured number inside the range.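

In this assay, among the compounds shown here, compound 2 has no number, so no step from compound 2 to compound 4 can be read. Whether the anilino change alters activity on the core of compound 2 stays open, and no measurement shown speaks to a cause.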